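The compounds below may be only part of what the source reports. "The series", "measured", "known", "first", "only" and "open" are said of these compounds alone.

Series notes, solubility.

Compound 1 `CNC(=O)c1cc(Oc2ccc3nc(Nc4cccc(C(C)(C)C)c4)ncc3c2)ccn1` is the parent of the set. In a physicochemical assay for solubility, at pH 7 (on this read-out higher numbers stand for higher solubility and lower numbers for lower solubility), compound 1 gives < 1000 nM, which is a limit of the assay and not a number. Compound 2 `CNC(=O)c1cc(Oc2ccc3nc(Nc4cccc(C(C)(C)C)c4)cnc3c2)ccn1` carries the same side chains on a rearranged core. In this assay compound 2 gives < 1000 nM, again a limit. Compound 3 `CNC(=O)c1cc(Oc2ccc3nc(Nc4cccc(C(F)(F)F)c4)ncc3c2)ccn1` replaces the tert-butyl of compound 1 with trifluoromethyl on an aromatic carbon. In this assay compound 3 gives < 1000 nM, a limit as well. Compound 3 thus stands at the limit of < 1000 nM in this assay, at which 3 of the 3 values shown sit, and the step that the two limits leave unreadable from compound 1 to compound 3 cannot be sized.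

Compound 4 `CNC(=O)c1cc(Oc2ccc3nc(Nc4ccc(C(F)(F)F)cc4)ncc3c2)ccn1` is not yet measured. The change from compound 3 is 4-(trifluoromethyl)phenyl in place of 3-(trifluoromethyl)phenyl on a nitrogen on an aromatic ring. For the measured compounds named here, no measured step bears on a change of this kind, and the one step in this assay that touches this aryl group is unreadable. Compound 4 is therefore expected to give 500 nM in this assay, with a range of 100 nM to 2000 nM, most likely reported as a limit. The step that the limit leaves unreadable from compound 3 to compound 4 is an estimate only, not beyond the scatter.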

Compound 4, solubility: < 1000 nM
Compound 4: only a limit was reported (the forecaster's own chance of this, stated with the estimate: 75%); the middle value lies beyond the limit too.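

No step can be read from compound 3 to compound 4 or from compound 1 to compound 4, since both ends of each pair are limits: the limit of < 1000 nM in this assay, at which 4 of the 4 values shown sit.

The compounds shown leave open where any of them truly stands in this assay, and whether moving the trifluoromethyl or replacing tert-butyl shifts the read-out at all.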